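A few compounds are considered here, and "the series" means these few. Any claim that something is new, unique, unknown or untested is made for them only; others in the source may bear on it.

The shared core carries a methylated lactam fused to an aminopyrimidine, and the three measured compounds vary both the group on the lactam nitrogen and the substituent on the pyrimidine. Compound 1 `CCC1C(=O)N(C)c2cnc(Nc3ccc(S(=O)(=O)NCC(C)C)cc3)nc2N1c1ccn(C)n1` bears a methylpyrazole on the lactam nitrogen and an isobutylsulfonamide on the aniline. In an assay for inhibition of serine/threonine-protein kinase PLK2 (Homo sapiens), read by FRET and Z'-LYTE, with a stated time of 1 h (a lower number here means a stronger inhibitor, a higher number a weaker inhibitor), compound 1 gives 311 nM. Compound 2 `CCCNS(=O)(=O)c1ccc(Nc2ncc3c(n2)N(C2CCCC2)[C@H](CC)C(=O)N3C)cc1` carries a cyclopentyl group on the lactam nitrogen and a propylsulfonamide on the aniline, and in this assay compound 2 gives 17.8 nM. Compound 3 `CC[C@@H]1C(=O)N(C)c2cnc(-n3ccc4cc(C(=O)NC)ccc43)nc2N1C1CCCC1` replaces the anilino link with an indole carrying a methylamide, and in this assay compound 3 gives 8.6 nM. Among these three numbers compound 2 stands second highest: compound 3 sits nearest with a lower number beyond the scatter, and compound 1 lies furthest away with a much higher number.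

The unmeasured compound 4 `CC[C@@H]1C(=O)N(C)c2cnc(Nc3ccc(S(=O)(=O)NCCO)cc3)nc2N1C1CCCC1` keeps the cyclopentyl lactam and the anilinosulfonamide of compound 2 and differs only at the chain on the sulfonamide nitrogen: hydroxy in place of methyl on a saturated chain carbon, two bonds along the chain from a sulfonamide nitrogen. Among the measured compounds shown here, no step between two measured compounds isolates this change. Because compound 2 gives 17.8 nM with a plain propyl chain, the exchange of its terminal methyl for hydroxy is expected to leave the number close to where it stands, with the step from compound 2 to compound 4 estimated at a 1.2-fold higher number from compound 2 to compound 4 (0.09 log units; within the scatter), within the scatter or a slight weakening. Compound 4 is therefore estimated at 22 nM, with a range from 8 nM to 60 nM.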

Compound 4, half-maximal inhibitory concentration: 7.86 nM
Compound 4: the middle estimate sits 2.8-fold (0.45 log units) above what was measured, and the stated range ends above it.
By their numbers in this assay, from the lowest: compounds 4 and 3 (each within the scatter of the next); then compound 2; then compound 1.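

Among the compounds shown here, compounds 2 and 4 are the first pair here to differ in one place, which lets the chain on the sulfonamide nitrogen be read on its own, apart from the changes that run together among the earlier compounds. In this assay, the change from propyl to 2-hydroxyethyl gives a 2.3-fold lower number from compound 2 to compound 4 (0.35 log units; beyond the scatter) and so lowers the number by a modest step, showing that this position on the chain responds to the exchange of methyl for hydroxy and that a hydroxy is accepted there without loss. No measurement at hand bears on the reason for this step.

The compounds shown leave open whether an amine or a carboxylic acid in place of the hydroxy, or a longer chain ending in a hydroxy, would move the number further, hold it or raise it. They also leave open whether the same exchange would lower the number on another background, such as that of compound 1, with its methylpyrazole on the lactam nitrogen and its isobutyl chain on the sulfonamide.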